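Urea series: replacing a biaryl arm with a small amine

The source may hold more compounds than are shown below. What is called first, only, known or untested is meant among the compounds shown, and "the series" means these compounds.

Measured compounds in an assay on isolated protein for binding affinity to P2Y purinoceptor 1 (Homo sapiens); on this read-out higher numbers stand for weaker inhibition and lower numbers for stronger inhibition:
compound 1 `COC(=O)C1(c2ccc(NC(=O)Nc3cccnc3Oc3ccccc3C(C)(C)C)cc2)CC1`, 7 nM
compound 2 `CC(C)(C)c1ccccc1Oc1ncccc1NC(=O)Nc1ccc(-c2ccccc2CO)cc1F`, 54 nM
compound 3 `CC(C)(C)c1ccccc1Oc1ncccc1NC(=O)Nc1ccc(N2CCCCC2)cc1`, 11 nM

Compound 2 gives the highest of the three numbers in this assay, standing beyond the scatter above both compound 3 and compound 1. Compound 4 `CN(C)Cc1ccc(NC(=O)Nc2cccnc2Oc2ccccc2C(C)(C)C)c(F)c1` has not yet been measured. It differs from compound 2 in one place: (dimethylamino)methyl in place of 2-(hydroxymethyl)phenyl on an aromatic carbon.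

Among the compounds with values here, only one measured step is available, and it does not cover this change. It is the exchange at the same position of the shared core between compound 1 and compound 3, a 1.6-fold higher number from compound 1 to compound 3 (0.20 log units; within the scatter), which shows that swapping one group for another there left the number within the scatter. The change from compound 2 to compound 4 is of a different kind, so it gives no direct guide. Since compound 2 sits well above compound 1 and compound 3, the expectation for compound 4 is a moderate move toward lower numbers, a 2.7-fold lower number from compound 2 to compound 4 (0.43 log units; beyond the scatter), though a step within the scatter cannot be excluded. The estimate for compound 4 is therefore 20 nM, with a range from 6 nM to 70 nM.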

Compound 4, inhibition constant in the P2Y purinoceptor 1 assay: 322 nM
Estimate against measurement, compound 4: 16-fold (1.21 log units) below, and the stated range ends below it.
By their numbers in the P2Y purinoceptor 1 assay, from the lowest: compounds 1 and 3 (each within the scatter of the next); then compound 2; then compound 4.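

In the P2Y purinoceptor 1 assay, this position proved sensitive to the exchange: a 6.0-fold higher number from compound 2 to compound 4 (0.78 log units; beyond the scatter). The earlier exchange, a 1.6-fold higher number from compound 1 to compound 3 (0.20 log units; within the scatter), had not shown this, so the position does not accept every group alike, and the (dimethylamino)methyl group does not keep the number given by the 2-(hydroxymethyl)phenyl group. In a physicochemical assay for lipophilicity, read by HPLC (a higher number here means a more lipophilic compound, a lower number a more polar compound), compound 2 gives 5.5 and compound 4 gives 4.2, so compound 4 is also the more polar of the pair, and the weaker binding may go with that drop, although a single pair cannot show it: the measured partition coefficient of compound 2, 5.5, and of compound 4, 4.2, a number 1.30 log units lower (beyond the scatter)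

The exchange removes the ring and the hydroxyl hydrogen-bond donor and brings in the amine all at once, and the compounds shown cannot separate these changes. A plain phenyl or a hydroxymethyl group at this position would begin to tell them apart.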